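Methoxy Position Change on a Weak Quinoline-Type Thiosemicarbazone

The source may report more compounds than this note shows. Statements on the series, on what has been measured and on what is new or still open speak of the compounds shown alone.

compound 1 `COc1cccc(NC(=S)N/N=C/c2ccc3ccccc3n2)c1`: 82400 nM
compound 2 `CN(C)C(=S)N/N=C/c1ccc2cccnc2n1`: 410 nM
compound 3 `CN(C)C(=S)N/N=C/c1cc2cccnc2s1`: 13400 nM

Of the compounds shown here, three have been measured in a functional assay on HT-29 cells (Homo sapiens) for antiproliferative activity, read by sulforhodamine B assay, with a stated time of 72 h; on this read-out higher numbers stand for weaker inhibition and lower numbers for stronger inhibition. Compound 1 gives 82400 nM, the highest number of the three, and so it is the weakest inhibitor in this set: compound 3 stands nearest with 13400 nM, a gap beyond the scatter, and compound 2 stands furthest with 410 nM. Going by the values given here, none of these three differs from another in only one place, so no single step between measured compounds can be read.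

Compound 4 `COc1ccccc1NC(=S)N/N=C/c1ccc2ccccc2n1` has not yet been measured in this assay. It differs from compound 1 as follows: 2-methoxyphenyl in place of 3-methoxyphenyl on an amide-type nitrogen. The same atoms are present in both, joined differently, with 2-methoxyphenyl in place of 3-methoxyphenyl on an amide-type nitrogen.

Among the compounds with values here, with no measured pair showing this kind of change, any expectation rests on compound 1 alone. The step from compound 1 to compound 4 is expected to be small, most likely within the scatter, with a slight lean toward a lower number, giving an estimated 1.5-fold lower number from compound 1 to compound 4 (0.18 log units; within the scatter). Compound 4 is therefore estimated at 55000 nM, with a range from 15000 nM to 160000 nM.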

Compound 4, half-maximal inhibitory concentration: > 100000 nM
Compound 4 ended at the assay's limit; the forecaster's own chance of this, stated with the estimate: 15%; middle value at least 1.8-fold (0.25 log units) from the limit.
By their numbers in this assay, from the lowest: compound 2; then compound 3; then compound 1. At a limit, above all of these: compound 4.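

Compound 4 gives > 100000 nM in this assay, and this value is a limit of the assay and not a number: the limit of > 100000 nM in this assay, at which 1 of the 4 values shown sits. Going by these compounds alone, the swap of 2-methoxyphenyl for 3-methoxyphenyl on the amide-type nitrogen is the first single-place change that can be read, and it gives an at least 1.2-fold higher number from compound 1 to compound 4 (0.08 log units; that floor lies within the scatter). From the compounds shown here alone, this shows that the change brought no stronger inhibition on this core, while the true size of the step stays unknown, since its floor is all that can be read and that floor does not separate the two compounds beyond the usual scatter.

The compounds shown leave open how far compound 4 really lies from compound 1, and so whether moving the methoxy group matters at all at this place or simply leaves both compounds weak. They also leave open whether an amine or a carboxylic acid on the phenyl ring, in place of the methoxy group, would give a lower number in this assay.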